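Extending the Amine Side Chain of Compound 3

This account rests on a few compounds, and the source may have more. Where it says the series, first, only, none or still open, it means among the compounds named here.

In a functional assay on LNCaP cells (Homo sapiens) for antiproliferative activity, read by WST assay, with a stated time of 3 days (on this read-out higher numbers stand for weaker inhibition and lower numbers for stronger inhibition), compound 1 `COc1cc(-c2oc3ccccc3c(=O)c2OC(C)C)cc(OC)c1OC` gives 8800 nM, compound 2 `CCCC(C)Oc1c(-c2cc(OC)c(OC)c(OC)c2)oc2ccccc2c1=O` gives 15100 nM and compound 3 `CCN(CC)CCCCOc1c(-c2cc(OC)c(OC)c(OC)c2)oc2ccccc2c1=O` gives 13500 nM. Compound 3 therefore stands among three values that lie within the scatter of one another. Compound 4 `CCCCN(CCCC)CCCCCOc1c(-c2cc(OC)c(OC)c(OC)c2)oc2ccccc2c1=O` differs from compound 3 in one place: (dibutylamino)methyl in place of diethylamino on a saturated chain carbon, four bonds along the chain from an oxygen on an aromatic ring. The change is (dibutylamino)methyl in place of diethylamino, on a saturated chain carbon, four bonds along the chain from an oxygen on an aromatic ring. Two measured side-chain swaps bear on this, a 1.5-fold higher number from compound 1 to compound 3 (0.19 log units; within the scatter) and a 1.1-fold lower number from compound 2 to compound 3 (0.05 log units; within the scatter), and both were small. Within the data shown here, no measured compound carries the dibutylamino group, so no step beyond the scatter is expected. The expected change is a 1.5-fold lower number from compound 3 to compound 4 (0.18 log units; within the scatter). For compound 4 the estimated value is 9000 nM, with an expected range of 3000 nM to 20000 nM.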

Compound 4, half-maximal inhibitory concentration: 7800 nM
Estimate against measurement, compound 4: 1.2-fold (0.06 log units) above; the range from low to high includes it.
By their numbers in this assay, from the lowest: compounds 4, 1, 3 and 2 (each within the scatter of the next).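

In this assay, putting (dibutylamino)methyl in place of diethylamino on this chain carbon gives a 1.7-fold lower number from compound 3 to compound 4 (0.24 log units; within the scatter), so even this larger amine end, with 10 heavy atoms instead of 5, does not separate the two compounds. The earlier steps shown here changed the whole group on the oxygen; this one shows that the far end of the amine chain can also change without a step beyond the scatter. Nothing measured here explains this result.

From the compounds shown here alone, the extra chain carbon and the butyl groups change together, so their separate contributions stay open. A ring amine such as piperidine or a carboxylic acid at the chain end also remains an open case at this position.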